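A few compounds are considered here, and "the series" means these few. Any claim that something is new, unique, unknown or untested is made for them only; others in the source may bear on it.

In a functional assay on MCF7 cells (Homo sapiens) for cytotoxicity, read by MTT assay, with a stated time of 72 h (on this read-out lower numbers stand for stronger inhibition and higher numbers for weaker inhibition), compound 1 `COc1ccc(OC)c(/C=C/C(=O)Nc2cc3c(Nc4ccc(F)c(Cl)c4)ncnc3cc2OC)c1` gives 34300 nM. Compound 2 `COc1cc(/C=C/C(=O)Nc2cc3c(Nc4ccc(F)c(Cl)c4)ncnc3cc2O[C@H]2CCOC2)cc(OC)c1OC` gives 28400 nM, which lies within the scatter of the number for compound 1, so the two stand level. Compound 3 `COc1ccc(/C=C/C(=O)Nc2cc3c(Nc4ccc(F)c(Cl)c4)ncnc3cc2OC)cc1` has no number and is reported as "not active" (no number reported).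

Compound 4 `O=C(/C=C/c1ccccc1[N+](=O)[O-])Nc1cc2c(Nc3ccc(F)c(Cl)c3)ncnc2cc1O[C@H]1CCOC1` differs from compound 2 in one place, with 2-nitrophenyl in place of 3,4,5-trimethoxyphenyl on a double-bonded chain carbon bound to a double-bonded chain carbon. Within the data shown here, no step between measured compounds isolates this change, so its size in this assay cannot be read directly. Compound 1 at 34300 nM and compound 2 at 28400 nM carry different groups in this place and still agree, whereas compound 3 goes against this picture by giving no number. No step beyond the scatter is therefore expected, in either direction, although a report without a number remains possible. The estimated change is a 1.1-fold higher number from compound 2 to compound 4 (0.02 log units; within the scatter), which is expected to stay within the scatter. For compound 4 the estimated value is 30000 nM, with an expected range from 12000 nM to 70000 nM.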

Compound 4, half-maximal inhibitory concentration: 28400 nM
The estimate for compound 4 lay 1.1-fold (0.02 log units) above the measured number, within the range that was stated.
By their numbers in this assay, from the lowest: compounds 2, 4 and 1 (each within the scatter of the next).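

In this assay, placing 2-nitrophenyl in place of 3,4,5-trimethoxyphenyl on a double-bonded chain carbon bound to a double-bonded chain carbon gives no change at the digits printed from compound 2 to compound 4 (within the scatter). Compound 1 and compound 2 differ in more than one place, so their agreement could not be tied to this position; this step holds the rest of the structure fixed and shows that the number stays level across two quite different aryl groups, one of 12 heavy atoms and one of 9. No measurement at hand explains why the number stays level here.

From the compounds shown here alone, it remains open whether an amine or a carboxylic acid on this phenyl ring, or a longer chain in its place, would move the number beyond the scatter. Also open is why compound 3 is reported as "not active" while compound 1 gives 34300 nM.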